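Cyclopropyl in Place of Phenyl on Compound 3

The compounds below may be only part of what the source reports. "The series", "measured", "known", "first", "only" and "open" are said of these compounds alone.

Compound 1, `COc1ccc(N/N=C2\CCC(C)n3c2ncc(C(=O)O)c3=O)cc1`, gives 0.8 umol/kg in a functional assay on the whole organism for inhibition, with Rattus norvegicus as the target; on this read-out higher numbers stand for an effect only at larger amounts of compound and lower numbers for an effect already at smaller amounts.
Compound 2, `CC1CC/C(=N\Nc2ccc([N+](=O)[O-])cc2)c2ncc(C(=O)O)c(=O)n21`, gives 0.8 umol/kg.
Compound 3, `CC1CC/C(=N\Nc2ccc(-c3ccccc3)cc2)c2ncc(C(=O)O)c(=O)n21`, gives 1.1 umol/kg.

Compound 3 has the highest of the three numbers, but only narrowly: a 1.4-fold higher number from compound 1 to compound 3 (0.14 log units; within the scatter) and a 1.4-fold higher number from compound 2 to compound 3 (0.14 log units; within the scatter), so none of the three compounds can be called stronger or weaker than another. All three share one core and differ only in the group on an aromatic carbon of the outer six-membered ring.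

Compound 4, `CC1CC/C(=N\Nc2ccc(C3CC3)cc2)c2ncc(C(=O)O)c(=O)n21`, continues this series: cyclopropyl in place of phenyl on an aromatic carbon. The group sits on an aromatic carbon of a six-membered aromatic ring of carbon only, para to a large group.

Every measured step bears on this change, since each swaps the group at the same position: no change at the digits printed from compound 1 to compound 2 (within the scatter), a 1.4-fold higher number from compound 1 to compound 3 (0.14 log units; within the scatter) and a 1.4-fold higher number from compound 2 to compound 3 (0.14 log units; within the scatter). Methoxy, nitro and phenyl, three groups of very different kind, left the number unchanged within the scatter, which suggests that cyclopropyl will do the same.

For compound 4 a value of 1 umol/kg is therefore expected, between 0.5 umol/kg and 2.2 umol/kg. This estimate means a 1.1-fold lower number from compound 3 to compound 4 (0.04 log units; within the scatter), a step expected to lie within the scatter.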

Compound 4, dose for 50% inhibition: 41.1 umol/kg
Compound 4: middle estimate off by 41-fold (1.61 log units), on the low side; the measured number lies above the stated range.
By their numbers in this assay, from the lowest: compounds 1, 2 and 3 (each within the scatter of the next); then compound 4.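

Going by these compounds alone, this position is less forgiving than the earlier compounds suggested. Methoxy, nitro and phenyl showed no difference beyond the scatter, yet with cyclopropyl there is a 37-fold higher number from compound 3 to compound 4 (1.57 log units; beyond the scatter) and a 51-fold higher number from compound 2 to compound 4 (1.71 log units; beyond the scatter) and also a 51-fold higher number from compound 1 to compound 4 (1.71 log units; beyond the scatter) in this assay on the same aromatic carbon. Measured against all three earlier groups, cyclopropyl needs far more compound for the same effect, so the group at this place can matter greatly after all. Nothing available explains why this one group stands so far from the other three.

On these data alone, whether an ethyl group, a tert-butyl group or an amine on this carbon would behave like cyclopropyl or like the earlier three stays open. So does whether the same jump would appear with a change elsewhere on the shared core.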